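A Bromo Swap on the Sulfonyl Series

The source may hold more compounds than are shown below. What is called first, only, known or untested is meant among the compounds shown, and "the series" means these compounds.

Measured so far in a functional assay on K562 cells (Homo sapiens) for inhibition, read by trypan blue exclusion, with a stated time of 72 h; on this read-out lower numbers stand for stronger inhibition and higher numbers for weaker inhibition:
compound 1 `Cn1c(=O)c(C(=O)Nc2ccc(F)cc2F)cc2cnc(Nc3ccc4[nH]ccc4c3)nc21` gives 5000 nM
compound 2 `Cn1c(=O)c(S(=O)(=O)c2ccc(F)cc2)cc2cnc(Nc3ccc4[nH]ccc4c3)nc21` gives 200 nM
compound 3 `Cc1ccc(S(=O)(=O)c2cc3cnc(Nc4ccc5[nH]ccc5c4)nc3n(C)c2=O)cc1` gives 750 nM

Compound 3, at 750 nM, holds the second highest of the three numbers. Compound 4 `Cn1c(=O)c(S(=O)(=O)c2ccc(Br)cc2)cc2cnc(Nc3ccc4[nH]ccc4c3)nc21` differs from it by bromo in place of methyl on an aromatic carbon, para to a large group. The closest measured change is a 3.8-fold higher number from compound 2 to compound 3 (0.57 log units; beyond the scatter), a modest step with methyl in place of fluoro. The steps from compound 1 replace a different group, so they say little here. Bromo itself is untested, but like fluoro it is a halogen, so a small move towards a lower number seems likely. The expected change is a 1.9-fold lower number from compound 3 to compound 4 (0.27 log units; within the scatter) in this assay, and it may not clear the scatter. For compound 4 the estimated value is 400 nM (130 nM to 1200 nM) in this series.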

Compound 4, half-maximal inhibitory concentration: 5000 nM
Beside the measured number, compound 4's estimate is 13-fold (1.10 log units) below it, outside the stated range (above it).
By their numbers in this assay, from the lowest: compound 2; then compound 3; then compounds 1 and 4 (each within the scatter of the next).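

Bromo in place of methyl gives a 6.7-fold higher number from compound 3 to compound 4 (0.82 log units; beyond the scatter) in this assay, and bromo in place of fluoro gives a 25-fold higher number from compound 2 to compound 4 (1.40 log units; beyond the scatter), so sharing the halogen label with fluoro does not bring bromo close to fluoro at this position. The sulfonyl link alone also secures no gain over the amide of compound 1, with no change at the digits printed from compound 1 to compound 4 (within the scatter) as the step between them. No supporting data here explain this sensitivity to a single atom. Still open, going by these compounds, is how a 4-chlorophenyl, a 4-methoxyphenyl or a plain phenyl group would read on the sulfonyl. On these data alone, an amine at this position is equally open.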